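The source may hold more compounds than are shown below. What is called first, only, known or untested is meant among the compounds shown, and "the series" means these compounds.

Among the compounds with values here, compound 3 `Cn1cnc(S(=O)(=O)N2C[C@@H]3[C@H](C2)[C@@]3(CNC(=O)c2ccccc2C(F)(F)F)CC2CC2)c1` stands lowest of the three numbers so far in an assay on isolated protein for inhibition of sodium- and chloride-dependent glycine transporter 1 (Homo sapiens); on this read-out lower numbers stand for stronger inhibition and higher numbers for weaker inhibition: compound 3 gives 5 nM, while compound 2 `Cn1cnc(S(=O)(=O)N2C[C@@H]3[C@H](C2)[C@@]3(CNC(=O)c2cc(Cl)cc(Cl)c2)CC2CC2)c1` gives 100 nM and compound 1 `CC(C)S(=O)(=O)N1C[C@@H]2[C@H](C1)[C@@]2(CNC(=O)c1ccc(Cl)cc1Cl)CC1CC1` gives 3400 nM. Within the data shown here, the one single-point step among them, a 20-fold lower number from compound 2 to compound 3 (1.30 log units; beyond the scatter), shows how much the aryl group on the carbonyl carbon can move this read-out. Compound 4 `Cn1cnc(S(=O)(=O)N2C[C@@H]3[C@H](C2)[C@@]3(CNC(=O)c2ccc(Cl)cc2)CC2CC2)c1` is the next variation on the same core: 4-chlorophenyl in place of 2-(trifluoromethyl)phenyl on a carbonyl carbon. Among the measured compounds shown here, no measured step covers exactly this exchange, so the only guide is that the aryl change from compound 2 to compound 3 was large. Compound 4 is therefore expected to land above compound 3, estimated at 60 nM (range 10 nM to 300 nM), a step of a 12-fold higher number from compound 3 to compound 4 (1.08 log units; beyond the scatter).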

Compound 4, half-maximal inhibitory concentration: 32 nM
Compound 4: the middle estimate sits 1.9-fold (0.27 log units) above what was measured; low and high end bracket the measured number.
By their numbers in this assay, from the lowest: compound 3; then compound 4; then compound 2; then compound 1.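

With 4-chlorophenyl on the carbonyl carbon, this assay gives a 6.4-fold higher number from compound 3 to compound 4 (0.81 log units; beyond the scatter) and a 3.1-fold lower number from compound 2 to compound 4 (0.49 log units; beyond the scatter), so this group falls in the middle of the three aryl groups carried by this core. All three exchanges at this position lie beyond the scatter, and 2-(trifluoromethyl)phenyl keeps the lowest number. No measurement shown here accounts for these differences. On these data alone, it remains open how a phenyl bearing a methoxy group or a nitrile, or a pyridine ring in place of the phenyl, would read in this assay.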